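The source may report more compounds than this note shows. Statements on the series, on what has been measured and on what is new or still open speak of the compounds shown alone.

In a functional assay on the whole organism with Mus musculus as the target, at a dose of 100 mg/kg by the intraperitoneal route (on this read-out higher numbers stand for more inhibition at the one dose given (going by the name of the read-out) and lower numbers for less inhibition), three compounds have been measured:

Compound 1, `CNC(=O)/C=C1\CCc2ccc(Br)cc21`: 0%
Compound 2, `O=C(/C=C1\CCc2ccc(F)cc21)N1CCCC1`: 33%
Compound 3, `NC(=O)/C=C1\CCc2ccc(Br)cc21`: 100%

Compound 3 stands highest of the three, beyond the scatter of both compound 2 and compound 1. Going by the values given here, the only step between compounds differing in one place is a number 100 percentage points higher from compound 1 to compound 3 (beyond the scatter), hydrogen in place of methyl on an amide-type nitrogen.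

Compound 4, `Cc1ccc2c(c1)/C(=C/C(N)=O)CC2`, differs from compound 3 elsewhere: methyl in place of bromo on an aromatic carbon. Among the compounds with values here, no measured step changes a group on the aromatic ring, so the step from compound 1 to compound 3 does not bear directly on this change. Since compound 3 already gives the highest number in this assay, a modest downward step is expected, a number 30 percentage points lower from compound 3 to compound 4 (beyond the scatter). Compound 4 is thus estimated at 70%, within 30% to 100%.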

Compound 4, a percentage reported as inhibition, in the whole organism at one dose (the size of the read-out at that dose, not a potency): 33%
Compound 4: middle estimate off by 37 percentage points, on the high side, and the stated range covers the measured number.
By their numbers in this assay, from the lowest: compound 1; then compounds 2 and 4 (each within the scatter of the next); then compound 3.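

Going by these compounds alone, the first change on the aromatic ring, with the unsubstituted amide kept, shows that in this assay this aromatic carbon is far from indifferent: the step is a number 67 percentage points lower from compound 3 to compound 4 (beyond the scatter). Bromo and methyl match in every count computed here, so those counts do not separate the two compounds, yet the read-out does. No measurement at hand explains the difference. Still open, as far as these compounds go, is how chloro, methoxy or trifluoromethyl on this same carbon would compare, and whether a hydrogen there would retain any of the inhibition.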